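Replacing the carboxyphenyl group with a piperidinylmethyl triazole

The source may report more compounds than this note shows. Statements on the series, on what has been measured and on what is new or still open speak of the compounds shown alone.

Measured in an ADME assay on SH-SY5Y cells (Homo sapiens) for cytotoxicity, read by MTT assay, with a stated time of 48 h; a lower number here means that less compound is needed, a higher number that more compound is needed for the effect:
- compound 1 `O=C(O)c1ccccc1-c1ccccc1C(=O)NCCCCCCCn1cc(-c2cccnc2)nn1`: > 500 nM (a limit)
- compound 2 `O=C(O)c1ccc(-c2ccccc2C(=O)NCCCCCCCn2cc(-c3cccnc3)nn2)cc1`: 224 nM
- compound 3 `O=C(NCCCCCCCn1cc(-c2cccnc2)nn1)c1ccccc1-n1cc(CN2CCC(O)CC2)nn1`: > 10000 nM (a limit)

Only compound 2 has a number, 224 nM. Its standing can therefore be read only against the two limits. Compound 1 gives > 500 nM, which is a limit. Compound 3 gives > 10000 nM, also a limit.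

The next compound is compound 4 `O=C(NCCCCCCCn1cc(-c2cccnc2)nn1)c1ccccc1-n1cc(CN2CCCCC2)nn1`. The change from compound 2 is 4-((piperidin-1-yl)methyl)-1H-1,2,3-triazol-1-yl in place of 4-carboxyphenyl on an aromatic carbon: 4-((piperidin-1-yl)methyl)-1H-1,2,3-triazol-1-yl in place of 4-carboxyphenyl, on an aromatic carbon of a six-membered aromatic ring of carbon only, ortho to a large group.

Going by the values given here, the only measured step is an at least 2.2-fold lower number from compound 1 to compound 2 (0.34 log units; beyond the scatter). It alters the carboxyphenyl group at this same place, so it shows that the number responds to changes here, but it introduces no triazole group. Among the compounds with values here, no measured step leads to compound 4. The closest guide is compound 3, which carries the same group with an added hydroxyl and stands at the limit of > 10000 nM.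

A clear move to a higher number is therefore expected in this assay. The expected step is a 13-fold higher number from compound 2 to compound 4 (1.13 log units; beyond the scatter). For compound 4 the estimate is 3000 nM, with an expected range from 400 nM to 20000 nM.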

Compound 4, half-maximal effective concentration: > 500 nM
Compound 4 ended at the assay's limit (the forecaster's own chance of this, stated with the estimate: 40%); the middle value is on the limit's open side.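

In this assay, exchanging 4-carboxyphenyl for 4-((piperidin-1-yl)methyl)-1H-1,2,3-triazol-1-yl gave an at least 2.2-fold higher number from compound 2 to compound 4 (0.34 log units; beyond the scatter), so the number at this place, ortho to a large group, responds to a change of group type and not only to moving the carboxylic acid around the phenyl ring. Compound 4 carries a limit and not a number, so this step gives only a minimum size, and the real distance from compound 2 stays undefined: the limit of > 500 nM in this assay, at which 2 of the 4 values shown sit. The steps linking compound 4 to compound 1 and to compound 3 cannot be read, as each has a limit at both ends, so nothing can be said about the hydroxy group that separates compound 3 from compound 4.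

The compounds shown leave open whether the higher number belongs to the loss of the carboxylic acid or to the arrival of the piperidinylmethyl triazole, as both changes occur together in this one step. On these data alone, a compound keeping the triazole but carrying a carboxylic acid in place of the piperidine would separate the two, and the effect of a shorter chain than the shared heptyl-length linker also remains unknown.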